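This account rests on a few compounds, and the source may have more. Where it says the series, first, only, none or still open, it means among the compounds named here.

Three compounds share one core and differ either in the group carried on the saturated chain carbon bound to the amine nitrogen in the ring or elsewhere in that shared core. Compound 1 `O=C(N[C@H]1CCN(Cc2ccc(OC(F)(F)F)cc2)C1)c1ccc(-c2cccs2)cc1` in an assay on frontal cortex for displacement of a labelled ligand from Adrenergic receptor alpha-1 (Rattus norvegicus) (a higher number here means a weaker inhibitor, a lower number a stronger inhibitor), gives 16000 nM. Compound 2 `O=C(N[C@H]1CCN(Cc2ccc(OC(F)(F)F)cc2)C1)c1cccc(-c2cccs2)c1` gives 1200 nM in this assay. Compound 3 `O=C(N[C@H]1CCN(Cc2ccccc2F)C1)c1ccc(-c2cccs2)cc1` gives 6900 nM in this assay. Compound 3 therefore stands second highest of the three numbers: its nearest neighbour is compound 1, whose number is higher by a gap beyond the usual scatter, and its furthest is compound 2, whose number is lower by a gap also beyond the scatter.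

Compound 4 `COc1cccc(CN2CC[C@H](NC(=O)c3ccc(-c4cccs4)cc3)C2)c1` has not yet been measured. It differs from compound 3 in one place: 3-methoxyphenyl in place of 2-fluorophenyl on a saturated chain carbon bound to an amine nitrogen in a ring. Within the data shown here, no measured pair shows this particular exchange, so there is no directly comparable step to draw on. All three measured numbers are weak, and the exchange keeps the aromatic ring on that chain carbon, so compound 4 is expected to stay near compound 3, with the step of a 1.2-fold higher number from compound 3 to compound 4 (0.06 log units; within the scatter) expected to fall within the scatter. The estimate for compound 4 in this assay is 8000 nM, with a range from 2500 nM to 25000 nM.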

Compound 4, inhibition constant: 920 nM
Compound 4: the middle estimate sits 8.7-fold (0.94 log units) above what was measured; the whole stated range lies above it.
By their numbers in this assay, from the lowest: compounds 4 and 2 (each within the scatter of the next); then compound 3; then compound 1.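

In this assay, among these compounds, putting 3-methoxyphenyl in place of 2-fluorophenyl on the saturated chain carbon bound to the amine nitrogen in the ring gives a 7.5-fold lower number from compound 3 to compound 4 (0.88 log units; beyond the scatter) and is the first single exchange at this position with a measured result. The step shows that this position is not indifferent to what the aromatic ring carries, even though both groups hold one six-membered aromatic ring of carbon only. The entering group has one hydrogen-bond acceptor and the leaving group none, but the exchange alters the atom on the ring, its place and that count together, and nothing measured here explains the size of the step.

As far as these compounds go, a 3-fluorophenyl or a 2-methoxyphenyl group on the same carbon would help separate the effect of the methoxy group from the effect of its place on the ring, so that question remains open. Also open, from the compounds shown here alone, is whether a 3-hydroxyphenyl or a 3-aminophenyl group would lower the number as far, and whether the same exchange would do the same on the core of compound 2.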